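The source may report more compounds than this note shows. Statements on the series, on what has been measured and on what is new or still open speak of the compounds shown alone.

Three esters of the same enone core have been tested in a functional assay on LFCl2A cells (Rattus norvegicus) for cytotoxicity; a higher number here means a weaker inhibitor, a lower number a stronger inhibitor. Compound 1 `CC/C=C\C/C=C\C/C=C\C/C=C\C/C=C\C/C=C\CCC(=O)OC[C@H]1O[C@H](CC2=CCCCC2)C=CC1=O` gives 50 nM, and compound 2 `CCCCCCCC/C=C\CCCCCCCC(=O)OC[C@H]1O[C@H](CC2=CCCCC2)C=CC1=O` gives 80 nM. Compound 3 `CCCCC/C=C\C/C=C\C/C=C\C/C=C\CCCC(=O)OC[C@H]1O[C@H](CC2=CCCCC2)C=CC1=O` gives 7000 nM, the highest of the three numbers, so it is the weakest inhibitor among them, with both gaps to the others lying beyond the scatter.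

Compound 4 `CCCCC/C=C\C/C=C\C/C=C\C/C=C\CCCC(=O)OC[C@H]1O[C@H](C2CCCC=C2C)C=CC1=O` has the same atoms as compound 3, joined differently: 2-methylcyclohex-2-en-1-yl in place of (cyclohex-1-en-1-yl)methyl on a saturated ring carbon. Within the data shown here, no measured pair shows this rearrangement, so its effect cannot be read from the data. The change is expected to move the number little, with the step of a 1.4-fold lower number from compound 3 to compound 4 (0.15 log units; within the scatter) estimated to stay within or only slightly beyond the scatter. Compound 4 is therefore expected to give about 5000 nM, somewhere between 1500 nM and 20000 nM.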

Compound 4, half-maximal inhibitory concentration: 1 nM
Estimate against measurement, compound 4: 5000-fold (3.70 log units) above; the whole stated range lies above it.
By their numbers in this assay, from the lowest: compound 4; then compounds 1 and 2 (each within the scatter of the next); then compound 3.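

In this assay, 2-methylcyclohex-2-en-1-yl in place of (cyclohex-1-en-1-yl)methyl gives a 7000-fold lower number from compound 3 to compound 4 (3.85 log units; beyond the scatter), so at this saturated ring carbon, how the same seven carbons are joined can change the number greatly. The earlier compounds shown here all carry (cyclohex-1-en-1-yl)methyl here and differ only in the ester chain, so they could not show this. Nothing available explains the size of the step.

As far as these compounds go, whether 2-methylcyclohex-2-en-1-yl has a similar effect with the ester chains of compound 1 and compound 2 remains open. So does how a cyclohexyl or phenyl group would behave at this carbon.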